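Aryl variation on the shared core: predicting the 2-chlorophenyl analogue

This account rests on a few compounds, and the source may have more. Where it says the series, first, only, none or still open, it means among the compounds named here.

Measured so far:
compound 1 `CCOC(=O)c1cnn(-c2nc(-c3ccc(OC)cc3)c(C#N)c(=O)n2C)c1N`, 59 ug/mL
compound 2 `CCOC(=O)c1cnn(-c2nc(-c3ccccc3F)c(C#N)c(=O)n2C)c1N`, 69 ug/mL
compound 3 `CCOC(=O)c1cnn(-c2nc(-c3cccs3)c(C#N)c(=O)n2C)c1N`, 79 ug/mL

For the measured compounds named here, in a functional assay, with a stated time of 20 min (on this read-out lower numbers stand for stronger inhibition and higher numbers for weaker inhibition), compound 3 gives the highest of the three numbers, yet a 1.3-fold higher number from compound 1 to compound 3 (0.13 log units; within the scatter) and a 1.1-fold higher number from compound 2 to compound 3 (0.06 log units; within the scatter), so no compound can be set apart from the others. Compound 4 `CCOC(=O)c1cnn(-c2nc(-c3ccccc3Cl)c(C#N)c(=O)n2C)c1N` carries 2-chlorophenyl in place of thiophen-2-yl on an aromatic carbon. The nearest measured step is a 1.1-fold higher number from compound 2 to compound 3 (0.06 log units; within the scatter), and a 1.2-fold higher number from compound 1 to compound 2 (0.07 log units; within the scatter) also concerns the same position; both are within the scatter. On that basis the expected step of a 1.1-fold lower number from compound 3 to compound 4 (0.05 log units; within the scatter) lies within the scatter, with no clear direction. Compound 4 is therefore estimated at 70 ug/mL, with a range from 40 ug/mL to 120 ug/mL.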

Compound 4, half-maximal inhibitory concentration: 78 ug/mL
Compound 4: middle estimate off by 1.1-fold (0.05 log units), on the low side; the range from low to high includes it.
By their numbers in this assay, from the lowest: compounds 1, 2, 4 and 3 (each within the scatter of the next).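

In this assay, for the compounds shown here, chloro in place of fluoro gives a 1.1-fold higher number from compound 2 to compound 4 (0.05 log units; within the scatter) and is the first change of a single halogen at this position. 2-chlorophenyl gives a 1.0-fold lower number from compound 3 to compound 4 (0.01 log units; within the scatter) in place of thiophen-2-yl and a 1.3-fold higher number from compound 1 to compound 4 (0.12 log units; within the scatter) in place of 4-methoxyphenyl, so all four aryl groups on this aromatic carbon, ortho to the cyano group, remain within the scatter of one another. No measured property bears on these results.

Going by these compounds, whether an amine or a carboxylic acid at this position would give a step beyond the scatter remains open.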